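A Dimethoxyphenyl Ring in Place of the Phenylethenyl Arm

A few compounds are considered here, and "the series" means these few. Any claim that something is new, unique, unknown or untested is made for them only; others in the source may bear on it.

Compound 1 `Cc1cc(O)c(C2=NN(c3ccc(S(N)(=O)=O)cc3)C(c3ccccc3Cl)C2)cc1Cl`: 1950 nM
Compound 2 `Cc1cc(O)c(C2=NN(c3ccc(S(N)(=O)=O)cc3)C(/C=C/c3ccccc3)C2)cc1Cl`: 14200 nM

In a functional assay on EKVX cells (Homo sapiens) for antiproliferative activity, with a stated time of 48 h (on this read-out higher numbers stand for weaker inhibition of growth and lower numbers for stronger inhibition of growth), compound 2 gives 14200 nM, the highest of the two numbers; its nearest neighbour, compound 1, sits at 1950 nM. Compound 3 `COc1ccc(C2CC(c3cc(Cl)c(C)cc3O)=NN2c2ccc(S(N)(=O)=O)cc2)cc1OC` differs from compound 2 in one place: 3,4-dimethoxyphenyl in place of 2-phenylethenyl on a saturated ring carbon. Going by the values given here, only one measured step touches this position, a 7.3-fold higher number from compound 1 to compound 2 (0.86 log units; beyond the scatter), where an aromatic ring sitting on the saturated ring carbon gave way to the phenylethenyl chain. Compound 3 brings an aromatic ring back onto that carbon, so a lower number is expected, with the step estimated at a 4.7-fold lower number from compound 2 to compound 3 (0.68 log units; beyond the scatter). Compound 3 is therefore estimated at 3000 nM, between 800 nM and 12000 nM.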

Compound 3, concentration for 50% growth inhibition: 4150 nM
Compound 3: middle estimate off by 1.4-fold (0.14 log units), on the low side; measured number inside the range.
By their numbers in this assay, from the lowest: compound 1; then compound 3; then compound 2.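

In this assay, 3,4-dimethoxyphenyl on the saturated ring carbon recovers only part of what the 2-phenylethenyl arm gives up, with a 3.4-fold lower number from compound 2 to compound 3 (0.53 log units; beyond the scatter) and still beyond the scatter. Yet the aromatic rings are not interchangeable here, as 3,4-dimethoxyphenyl falls short of 2-chlorophenyl, with a 2.1-fold higher number from compound 1 to compound 3 (0.33 log units; beyond the scatter) in the weaker direction. The data offer no explanation for this order of the three groups.

The two rings differ in more than one substituent, so the separate contributions of the chlorine and the two methoxy groups remain unresolved. A plain phenyl ring, or one carrying a single methoxy group or an amine, would help separate them.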